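The source may hold more compounds than are shown below. What is called first, only, known or untested is meant among the compounds shown, and "the series" means these compounds.

Measured compounds:
- compound 1, `COc1ccc2c(O[C@H]3C[C@H]4C(=O)N(C)CCCC/C=C/[C@@H]5C[C@@]5(C(=O)NS(=O)(=O)C5(C)CC5)NC(=O)N4C3)cc(-c3nc(C4CCC4)cs3)nc2c1Cl`: 75000 nM
- compound 2, `COc1ccc2c(O[C@H]3C[C@H]4C(=O)N(C)CCCC/C=C/[C@@H]5C[C@@]5(C(=O)NS(=O)(=O)C5CC5)NC(=O)N4C3)cc(-c3csc(C(F)(F)F)n3)nc2c1C`: 75000 nM
- compound 3, `COc1ccc2c(O[C@H]3C[C@H]4C(=O)N(C)CCCC/C=C/[C@@H]5C[C@@]5(C(=O)NS(=O)(=O)C5(C)CC5)NC(=O)N4C3)cc(-n3cc(C(C)C)cn3)nc2c1C`: 9610 nM

The three compounds share one large macrocyclic core and were tested in an ADME assay on Huh-7 cells (Homo sapiens) for cytotoxicity, read by colorimetric assay; on this read-out higher numbers stand for lower toxicity in this test and lower numbers for higher toxicity in this test. Compound 1 gives 75000 nM, and compound 2 gives 75000 nM, so these two stand level with each other at the digits shown and together are the highest of the three numbers. Compound 3 gives 9610 nM, a number that lies well beyond the usual scatter below compound 1.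

Compound 4, `COc1ccc2c(O[C@H]3C[C@H]4C(=O)N(C)CCCC/C=C/[C@@H]5C[C@@]5(C(=O)NS(=O)(=O)C5(C)CC5)NC(=O)N4C3)cc(-n3cc(C(F)(F)F)cn3)nc2c1Cl`, has not yet been measured in this assay. It differs from compound 1 in one place: 4-(trifluoromethyl)-1H-pyrazol-1-yl in place of 4-cyclobutyl-1,3-thiazol-2-yl on an aromatic carbon. The change brings in a pyrazolyl group, which compound 3 also carries, though compound 3 also differs from compound 4 elsewhere, so no clean comparison exists. Given that compound 3 gives 9610 nM, a step downward from compound 1 is expected, of moderate size: a 2.5-fold lower number from compound 1 to compound 4 (0.40 log units; beyond the scatter). The estimate for compound 4 is 30000 nM, with a range from 8000 nM to 75000 nM.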

Compound 4, half-maximal cytotoxic concentration: 21900 nM
For compound 4 the middle estimate is 1.4-fold (0.14 log units) above the measured one; the range from low to high includes it.
By their numbers in this assay, from the lowest: compound 3; then compound 4; then compounds 1 and 2 (each within the scatter of the next).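

In this assay, putting 4-(trifluoromethyl)-1H-pyrazol-1-yl in place of 4-cyclobutyl-1,3-thiazol-2-yl, on the aromatic carbon next to the ring nitrogen, gives a 3.4-fold lower number from compound 1 to compound 4 (0.53 log units; beyond the scatter). Among the compounds shown here, this is the first comparison here that differs in one place, and it shows that a change at this position alone can move the number beyond the scatter, toward higher toxicity in this test, even though the counts of heavy atoms, hydrogen-bond donors and hydrogen-bond acceptors stay the same. No measurement available here accounts for this step.

From the compounds shown here alone, the ring and its substituent change together, so the shares of the pyrazolyl ring and the trifluoromethyl group in the step remain open. Also open, going by these compounds, is how a pyrazolyl ring carrying an amine or a carboxylic acid would read in this assay at this position.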